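This account rests on a few compounds, and the source may have more. Where it says the series, first, only, none or still open, it means among the compounds named here.

Compound 1, `CCC1(Cc2ccccc2)OS(=O)(=O)C=C1OCC1CCCCC1`: >= 200000 nM in an ADME assay on HEL cells (Homo sapiens) for cytotoxicity, with a stated time of 3 days (a higher number here means that more compound is tolerated, a lower number that less compound is tolerated), a limit of the assay.
Compound 2, `CCC1(Cc2ccccc2)OS(=O)(=O)C=C1OCCCc1ccccc1`: >= 20000 nM in this assay, also a limit.

Compound 2 thus stands only at a limit in this assay: the limit of >= 20000 nM in this assay, at which 1 of the 2 values shown sits. Compound 1 stands at the other limit: the limit of >= 200000 nM in this assay, at which 1 of the 2 values shown sits. Within the data shown here, the single measured step, a step that the two limits leave unreadable from compound 1 to compound 2, cannot be read as a number. Compound 3 is `CCC1(Cc2ccccc2)OS(=O)(=O)C=C1OCC=C(C)C`; its change from compound 2: 2-methylprop-1-en-1-yl in place of phenethyl on a saturated chain carbon bound to an oxygen on an unsaturated carbon. No measured step carries this change, and both shown values are limits, so nothing fixes a size or direction. Compound 3 is expected to remain well tolerated, in line with the limits of compound 1 and compound 2, and the estimate implies a step that the limit leaves unreadable from compound 2 to compound 3 only because the reported value of compound 2 is a floor. The estimate for compound 3 in this assay is 100000 nM, within 20000 nM to 300000 nM.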

Compound 3, minimum cytotoxic concentration: 400000 nM
Compound 3: the middle estimate sits 4.0-fold (0.60 log units) below what was measured; measured number above the stated range.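

Neither the step from compound 1 to compound 3 nor the step from compound 2 to compound 3 can be read as a size; compound 1 and compound 2 stand only at limits. The compounds shown leave open how far the cyclohexyl, phenethyl and 2-methylprop-1-en-1-yl compounds lie apart in this assay.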